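Hydroxy to methoxy on the imine aryl of compound 2

This account rests on a few compounds, and the source may have more. Where it says the series, first, only, none or still open, it means among the compounds named here.

Compound 1 `N#Cc1ncn(-c2ccc(F)cc2)c1/N=C/c1ccc([N+](=O)[O-])cc1`: 15900 nM
Compound 2 `N#Cc1ncn(-c2ccc(F)cc2)c1/N=C/c1ccc(O)cc1`: 20400 nM

Compound 2 in a functional assay on T47D cells (Homo sapiens) for antiproliferative activity, read by MTT assay, with a stated time of 48 h (a lower number here means a stronger inhibitor, a higher number a weaker inhibitor), sits alongside compound 1, the two values within the usual scatter of each other. Compound 3 `COc1ccc(/C=N/c2c(C#N)ncn2-c2ccc(F)cc2)cc1` differs from compound 2 by methyl in place of hydrogen on an oxygen on an aromatic ring. For the measured compounds named here, no measured step covers this change directly. Going by the values given here, the only step, a 1.3-fold higher number from compound 1 to compound 2 (0.11 log units; within the scatter), shows that changing the group at this position moved the number little. A step of no more than the scatter is therefore expected, a 1.1-fold lower number from compound 2 to compound 3 (0.05 log units; within the scatter), with no direction favoured. Compound 3 is estimated at 18000 nM, range 7000 nM to 45000 nM.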

Compound 3, half-maximal inhibitory concentration: 19400 nM
Estimate against measurement, compound 3: 1.1-fold (0.03 log units) below, within the range that was stated.
By their numbers in this assay, from the lowest: compounds 1, 3 and 2 (each within the scatter of the next).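

Methyl in place of hydrogen on the oxygen leaves the number in this assay unresolved from that of the hydroxy compound (a 1.1-fold lower number from compound 2 to compound 3 (0.02 log units; within the scatter)). Methoxy in place of nitro gives the same reading (a 1.2-fold higher number from compound 1 to compound 3 (0.09 log units; within the scatter)), so all three groups now lie within the scatter of one another, and the hydroxy hydrogen is not required to hold this level. Nothing available explains this flat response.

From the compounds shown here alone, whether an amine, a carboxylic acid or a longer alkoxy chain on this aromatic carbon would move the number stays open. So does whether any group here can depart from this level at all.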